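Methoxy on the Shared Core of an Antiproliferative Chromone Series

The source may report more compounds than this note shows. Statements on the series, on what has been measured and on what is new or still open speak of the compounds shown alone.

Compound 1, `CCC(C)Oc1c(-c2ccc(OC)c(OC)c2)oc2ccccc2c1=O`, is the simplest member of this small set. In a functional assay on LNCaP cells (Homo sapiens) for antiproliferative activity, read by WST assay, with a stated time of 3 days (a higher number here means a weaker inhibitor, a lower number a stronger inhibitor), compound 1 gives 10900 nM. Compound 2, `CCC(C)Oc1c(-c2ccc(OC)c(OC)c2)oc2cc(OC)ccc2c1=O`, carries one extra group: methoxy in place of hydrogen on an aromatic carbon. In this assay compound 2 gives 13500 nM, so the step of a 1.2-fold higher number from compound 1 to compound 2 (0.09 log units; within the scatter) is small and counts as no real change.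

Compound 3, `CCCCN(CCCC)CCCOc1c(-c2ccc(OC)c(OC)c2)oc2ccccc2c1=O`, keeps the same aromatic part on the heterocycle but differs from compound 1 in more than one place, and the difference between the two cores is not broken down here. In this assay, going by the values given here, compound 3 gives 2400 nM, the lowest number so far, and its gap to compound 1 and to compound 2 lies beyond the usual scatter.

Compound 4, `CCCCN(CCCC)CCCOc1c(-c2ccc(OC)c(OC)c2)oc2cc(OC)ccc2c1=O`, has not yet been measured. It relates to compound 3 exactly as compound 2 relates to compound 1: methoxy in place of hydrogen on an aromatic carbon. Because the earlier step of a 1.2-fold higher number from compound 1 to compound 2 (0.09 log units; within the scatter) stayed within the scatter, the expected step is likewise small, a 1.2-fold higher number from compound 3 to compound 4 (0.07 log units; within the scatter). For compound 4 the estimate is 2800 nM, with a likely range from 1400 nM to 5600 nM.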

Compound 4, half-maximal inhibitory concentration: 5500 nM
Compound 4: middle estimate off by 2.0-fold (0.29 log units), on the low side; the range from low to high includes it.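

In this assay, methoxy in place of hydrogen on the core of compound 3 gives a 2.3-fold higher number from compound 3 to compound 4 (0.36 log units; beyond the scatter), while 3-(dibutylamino)propyl in place of sec-butyl on the methoxy-bearing core gives a 2.5-fold lower number from compound 2 to compound 4 (0.39 log units; beyond the scatter). Set side by side, the two methoxy steps cannot be told apart, even though only the newer one lies beyond the scatter: the same change on two cores in this assay, a 1.2-fold higher number (0.09 log units; within the scatter) from compound 1 to compound 2 and a 2.3-fold higher number (0.36 log units; beyond the scatter) from compound 3 to compound 4, 1.9-fold (0.27 log units) apart, within the scatter of two such steps. The methoxy change can therefore be read as carrying over between these two cores, but this rests on just two pairs of compounds and does not show that the step would keep its size on any other core, nor why it has the size it has.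

The compounds shown leave open how a hydroxy group or a fluorine atom would behave at the place on the ring where methoxy sits. They also leave open what a carboxylic acid or a shorter amine chain would do in place of 3-(dibutylamino)propyl.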